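Amino for nitro on two chalcone cores

The compounds below may be only part of what the source reports. "The series", "measured", "known", "first", "only" and "open" are said of these compounds alone.

Compound 1 `COc1cccc(/C=C/C(=O)c2ccc(OC)c([N+](=O)[O-])c2)c1` and compound 2 `COc1cccc(/C=C/C(=O)c2ccc(OC)c(N)c2)c1` share one core and differ in a single place, (amino in place of nitro on an aromatic carbon). In a functional assay on B16 cells (Mus musculus) for cytotoxicity, read by MTT assay, with a stated time of 3 days (a lower number here means a stronger inhibitor, a higher number a weaker inhibitor), compound 1 gives only a limit of the assay, > 100000 nM. Compound 2 gives 33000 nM in this assay. The resulting step, an at least 3.0-fold lower number from compound 1 to compound 2 (0.48 log units; beyond the scatter), is known only as a bound because of the limit of > 100000 nM in this assay, at which 2 of the 3 values shown sit.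

Compound 3 `COc1ccc(C(=O)/C=C/c2cc(OC)c(OC)c(OC)c2)cc1[N+](=O)[O-]` carries a different core; the difference between the core of compound 1 and the core of compound 3 is not broken down here. In this assay compound 3 gives only a limit of the assay, > 100000 nM. Compound 4 `COc1ccc(C(=O)/C=C/c2cc(OC)c(OC)c(OC)c2)cc1N` has not yet been measured and differs from compound 3 by amino in place of nitro on an aromatic carbon. The surroundings are the same in every word as for the change from compound 1 to compound 2: on an aromatic carbon of a six-membered aromatic ring of carbon only, ortho to a methoxy group, meta to a large group. It is therefore the same change, recurring among these compounds.

For the measured compounds named here, for compound 4 in this assay a step of an at least 3.3-fold lower number from compound 3 to compound 4 (0.52 log units; beyond the scatter) is expected, resting on the one measured instance of this change, an at least 3.0-fold lower number from compound 1 to compound 2 (0.48 log units; beyond the scatter). As far as these compounds go, since compound 3 itself sits at a limit, the true starting point is unknown and the expected step is correspondingly uncertain. Compound 4 is estimated at 30000 nM, with a range from 5000 nM to 100000 nM.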

Compound 4, half-maximal inhibitory concentration: 67000 nM
Estimate against measurement, compound 4: 2.2-fold (0.35 log units) below, within the range that was stated.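

Amino in place of nitro on an aromatic carbon can now be read on two cores in this assay, and on the core of compound 3 it gives an at least 1.4-fold lower number from compound 3 to compound 4 (0.17 log units; that floor lies within the scatter). Both readings point to a lower number with amino, which fits the change carrying over to the second core, but the floor of the new step alone does not establish a real change, and no transferable size for the step follows from the two cores: the same change on two cores in this assay, an at least 3.0-fold lower number (0.48 log units; beyond the scatter) from compound 1 to compound 2 and an at least 1.4-fold lower number (0.17 log units; that floor lies within the scatter) from compound 3 to compound 4; the limit leaves it open whether they differ The true size of the step on either core remains unknown because both nitro compounds give limits rather than numbers: the limit of > 100000 nM in this assay, at which 2 of the 4 values shown sit.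

The compounds shown cover only nitro and amino at this position, so it remains open whether a hydroxyl, an acetamide or a dimethylamino group there would give a number in line with amino or with nitro. As far as these compounds go, it also remains open whether the direction seen on these two cores holds on a core with a different methoxy pattern on the second aromatic ring, or with a nitro compound that gives a number rather than a limit in this assay.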